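The source may hold more compounds than are shown below. What is called first, only, known or untested is meant among the compounds shown, and "the series" means these compounds.

Compound 1, `Clc1nc(NC2CC2)c2ncn(C3CCCCO3)c2n1`, gives 11.9% in a functional assay on the whole organism with Mus musculus as the target, with a stated time of 90 min, at a dose of 25 umol/kg by the oral route; on this read-out higher numbers stand for a stronger effect at the one dose given and lower numbers for a weaker effect.
Compound 2, `O=C(CN(c1nc(Cl)nc2c1ncn2C1CCCCO1)C1CC1)NCC(=O)OCc1ccccc1`, gives 25.9% in this assay.
Compound 3, `O=C(OCc1ccccc1)[C@@H]1CCCN1C(=O)CN(c1nc(Cl)nc2c1ncn2C1CCCCO1)C1CC1`, gives 23.3% in this assay.

Among these three numbers compound 2 stands highest, but compound 3 lies within the scatter of it, so the two cannot be told apart; only compound 1 lies beyond the scatter below compound 2. Compound 4, `CC(C)[C@H](NC(=O)CN(c1nc(Cl)nc2c1ncn2C1CCCCO1)C1CC1)C(=O)OCc1ccccc1`, has not yet been measured. It differs from compound 2 by isopropyl in place of hydrogen on a saturated chain carbon bound to an amide-type nitrogen and a carbonyl carbon. Compounds 2 and 3 show that changing the group carried on the amide-type nitrogen leaves the read-out within the scatter, so no step beyond the scatter is expected here. Compound 4 is estimated at 25%, between 12% and 40%, which means an expected step of a number 0.9 percentage points lower from compound 2 to compound 4 (within the scatter).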

Compound 4, a percentage reported as activity, at one dose (the size of the read-out at that dose, not a potency): 30.1%
Estimate against measurement, compound 4: 5.1 percentage points below; the range from low to high includes it.
By their numbers in this assay, from the lowest: compound 1; then compounds 3, 2 and 4 (each within the scatter of the next).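

Isopropyl in place of hydrogen on a saturated chain carbon bound to an amide-type nitrogen and a carbonyl carbon gives a number 4.2 percentage points higher from compound 2 to compound 4 (within the scatter) in this assay. This position therefore takes an isopropyl group, with its 3 carbon atoms, without a step beyond the scatter. Nothing measured here speaks to the reason for this result. The compounds shown leave open whether an amine, a carboxylic acid or a longer chain in the same place would move the read-out beyond the scatter.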